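Moving the halogen on the phenoxy tail

The source may hold more compounds than are shown below. What is called first, only, known or untested is meant among the compounds shown, and "the series" means these compounds.

Measured so far:
- compound 1, `NC1=NC2(CCOCC2)N(OCCCOc2ccccc2)C(N)=N1`: > 90%
- compound 2, `NC1=NC2(CCOCC2)N(OCCCOc2cc(Cl)c(Cl)cc2Cl)C(N)=N1`: > 90%
- compound 3, `NC1=NC2(CCOCC2)N(OCCCOc2ccccc2Br)C(N)=N1`: 83.8%

All three compounds share one core and differ only in the aromatic ring at the end of the ether chain. In an assay on isolated protein for inhibition of Dihydrofolate reductase (Homo sapiens), read by spectrophotometry, using NADPH, with stated times of 5 s and 6 min, tested at 5 uM (on this read-out lower numbers stand for a weaker effect and higher numbers for a stronger effect at the one concentration tested), compound 1 gives > 90%, which is a limit of the assay and not a number. Compound 2 likewise gives > 90%, again a limit. Within the data shown here, compound 3 gives 83.8%, the only plain number among the three; the other two values sit at the limit of > 90% in this assay, at which 2 of the 3 values shown sit. The step of a number at least 6.2 percentage points lower from compound 1 to compound 3 (that floor lies within the scatter) and the step of a number at least 6.2 percentage points lower from compound 2 to compound 3 (that floor lies within the scatter) both carry only a floor, and the step that the two limits leave unreadable from compound 1 to compound 2 cannot be read at all.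

Compound 4, `NC1=NC2(CCOCC2)N(OCCCOc2cccc(Cl)c2)C(N)=N1`, is not yet measured. It differs from compound 3 by 3-chlorophenyl in place of 2-bromophenyl on an oxygen on a saturated carbon. The two readable steps, from compound 1 and from compound 2 to compound 3, are the ones that bear on this change, and both are small enough that their floors lie within the scatter. Compound 4 is therefore expected to stay close to compound 3, with a step of a number 2.2 percentage points higher from compound 3 to compound 4 (within the scatter) expected in this assay. The estimate for compound 4 is 86%, between 72% and 95%.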

Compound 4, a percentage reported as inhibition, at one concentration (the size of the read-out at that concentration, not a potency): 83.2%
Compound 4: the middle estimate sits 2.8 percentage points above what was measured; the measured number falls inside the stated range.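

In this assay, 3-chlorophenyl in place of 2-bromophenyl gives a number 0.6 percentage points lower from compound 3 to compound 4 (within the scatter), so changing the halogen and its ring position together leaves these two tails indistinguishable at the one concentration tested. Starting from the plain phenyl tail, 3-chlorophenyl gives a number at least 6.8 percentage points lower from compound 1 to compound 4 (that floor lies within the scatter), and starting from the 2,4,5-trichlorophenyl tail, 3-chlorophenyl gives a number at least 6.8 percentage points lower from compound 2 to compound 4 (that floor lies within the scatter). Both of these steps carry only a floor, and their true size stays unknown because each begins at a limit of the assay and not at a number: the limit of > 90% in this assay, at which 2 of the 4 values shown sit.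

The compounds shown do not separate the identity of the halogen from its ring position, as the bromo and chloro groups here also sit at different places, and a single-concentration read-out does not give a potency for any of them. Also open, as far as these compounds go, is how the read-out would respond to a ring carrying a methoxy group, an amine or a carboxylic acid, or to a longer chain between the shared core and the aromatic ring.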